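The compounds below may be only part of what the source reports. "The series", "measured", "known", "first", "only" and "open" are said of these compounds alone.

Compound 1, `C=C(C(=O)c1ccc(OC)cc1)C(OC(C)=O)c1ccc(Cl)cc1Cl`: 17600 nM
Compound 2, `C=C(C/C(=C\c1ccc(C)cc1)C(=O)c1ccccc1)C(=O)c1ccccc1`: 20900 nM

Both numbers come from a functional assay on A549 cells (Homo sapiens) for inhibition, read by XTT assay, with a stated time of 48 h; a lower number here means a stronger inhibitor, a higher number a weaker inhibitor. Compound 2 stands at the top end of the two numbers, yet its gap to compound 1 lies within the scatter of repeated measurements, so on these data the two compounds cannot be told apart. Compound 1 and compound 2 also differ from each other in several places at once, so nothing about any single structural change can be read from their pair.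

Compound 3, `C=C(C/C(=C\c1ccc(OC(=O)c2ccccc2)cc1)C(=O)c1ccccc1)C(=O)c1ccccc1`, has not yet been measured in this assay. Relative to compound 2, the change is benzoyloxy in place of methyl on an aromatic carbon. Going by the values given here, no measured pair in this set isolates a change of this kind, so there is no earlier step to lean on. With nothing pointing in either direction, the expectation is a step no larger than the scatter, a 1.0-fold lower number from compound 2 to compound 3 (0.02 log units; within the scatter). Compound 3 is therefore expected to give roughly 20000 nM in this assay, with a likely range from 6000 nM to 65000 nM.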

Compound 3, half-maximal inhibitory concentration: 44400 nM
Compound 3: middle estimate off by 2.2-fold (0.35 log units), on the low side; low and high end bracket the measured number.
By their numbers in this assay, from the lowest: compounds 1 and 2 (each within the scatter of the next); then compound 3.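

In this assay, putting benzoyloxy in place of methyl on this aromatic carbon, para to a large group, gives a 2.1-fold higher number from compound 2 to compound 3 (0.33 log units; beyond the scatter), the first change in a single place among these compounds that can be read at all. The step is modest, but it shows that this position is not indifferent to what sits there, and that here the much larger group, with 9 heavy atoms against 1 and a further six-membered aromatic ring, comes with weaker inhibition rather than stronger. No measurement at hand gives a reason for this step.

With one replacement at this position, the compounds shown cannot separate the roles of the added ring, the two hydrogen-bond acceptors and the sheer number of added atoms, since all three enter together. From the compounds shown here alone, a hydroxyl group, an amine or a plain phenyl ring on the same carbon would each change only part of that package, so how the number responds to such groups at this position remains open.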